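Methylation of a ring hydroxy group in a pyrazinoyl guanidine series

A few compounds are considered here, and "the series" means these few. Any claim that something is new, unique, unknown or untested is made for them only; others in the source may bear on it.

Measured so far:
compound 1, `C=CCNc1nc(N)c(C(=O)N=C(N)N)nc1Cl`, 16%
compound 2, `NC(N)=NC(=O)c1nc(Cl)c(O)nc1N`, "not determined" (no result reported)

In an assay for inhibition of acid-sensing ion channel 3 (Homo sapiens), read by patch clamp, tested at 1 uM (on this read-out higher numbers stand for more inhibition at the one concentration tested (going by the name of the read-out) and lower numbers for less inhibition), compound 1 gives 16%. Compound 2, `NC(N)=NC(=O)c1nc(Cl)c(O)nc1N`, shares the core of compound 1 but carries a hydroxy group in place of the allylamino group; in this assay compound 2 gives "not determined" (no result reported), so it stands without a number, and its ground can only be inferred from compound 1. Compound 3, `COc1nc(N)c(C(=O)N=C(N)N)nc1Cl`, differs from compound 2 in one place: methyl in place of hydrogen on an oxygen on an aromatic ring. Among the measured compounds shown here, with no measured step to draw on, the size of the step from compound 2 to compound 3 in this assay cannot be fixed; a change within the scatter is as plausible as a small one in either direction. Taking the weak result of compound 1, 16%, as the only anchor, compound 3 is expected to give about 18%, most likely between 0% and 45%.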

Compound 3, a percentage reported as inhibition, at one concentration (the size of the read-out at that concentration, not a potency): 21%
The estimate for compound 3 lay 3 percentage points below the measured number; the range from low to high includes it.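

In this assay, putting methoxy in place of allylamino on an aromatic carbon gives a number 5 percentage points higher from compound 1 to compound 3 (within the scatter) and so does not separate the two groups at this place. Compound 3 thus gives this position a second measured substituent, one joined through oxygen, while the step from hydroxy to methoxy cannot be read, as compound 2 has no number. No measurement shown offers an explanation for the result.

The compounds shown leave open what the methyl on the oxygen contributes on its own and whether a number for compound 2 would stand apart from that of compound 3. They also leave open whether a carboxylic acid or a longer alkoxy chain on this aromatic carbon would move the inhibition beyond the usual scatter.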